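Swapping the amine side chain for chloro on the core

The compounds below may be only part of what the source reports. "The series", "measured", "known", "first", "only" and "open" are said of these compounds alone.

Within the data shown here, compound 3 `C=CCOc1ccc2c(NCCCN(C)C)ccnc2c1` gives 3990 nM in a functional assay on HepG2 cells (Homo sapiens) for cytotoxicity, read by MTT assay, with a stated time of 48 h (a lower number here means a stronger inhibitor, a higher number a weaker inhibitor), the highest of the three numbers so far, though compound 2 `Clc1ccnc2cc(OCc3ccccc3)ccc12` with 2680 nM and compound 1 `CCCCCCOc1ccc2c(Cl)ccnc2c1` with 2420 nM both sit within the scatter of it, so no order among the three is established.

Compound 4 `C=CCOc1ccc2c(Cl)ccnc2c1` differs from compound 3 in one place: chloro in place of (3-(dimethylamino)propyl)amino on an aromatic carbon. The only measured step among these compounds, a 1.1-fold higher number from compound 1 to compound 2 (0.04 log units; within the scatter), concerns a different part of the molecule and so does not bear on this change; no pair in the set isolates the exchange of the amine side chain for chloro. What the data do show is that compound 1 and compound 2, which carry the chloro that enters in compound 4, give numbers in this assay within the scatter of compound 3.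

On that basis the step from compound 3 to compound 4 is expected to be small, and the estimate is a 1.4-fold lower number from compound 3 to compound 4 (0.14 log units; within the scatter), with no direction claimed beyond the scatter. Compound 4 is accordingly expected to give about 2900 nM in this assay, most likely between 1200 nM and 7000 nM.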

Compound 4, half-maximal inhibitory concentration: 2770 nM
Compound 4: the middle estimate sits 1.0-fold (0.02 log units) above what was measured; the range from low to high includes it.
By their numbers in this assay, from the lowest: compounds 1, 2, 4 and 3 (each within the scatter of the next).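

Among these compounds, with this pair, the exchange on the aromatic carbon opposite the ring nitrogen can be read directly for the first time: in this assay, chloro in place of (3-(dimethylamino)propyl)amino gives a 1.4-fold lower number from compound 3 to compound 4 (0.16 log units; within the scatter), so this change, with the loss of the whole side chain and its ring-free amine groups, does not separate the two compounds. Compound 4 also widens the earlier comparison of groups on the saturated chain carbon bound to the oxygen, where vinyl in place of phenyl gives a 1.0-fold higher number from compound 2 to compound 4 (0.01 log units; within the scatter) and vinyl in place of pentyl gives a 1.1-fold higher number from compound 1 to compound 4 (0.06 log units; within the scatter), so vinyl, phenyl and pentyl are not told apart when chloro sits on the shared core. No independent measurement bears on these results.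

As far as these compounds go, the exchange of the side chain for chloro rests on a single pair, so it remains open whether it would read the same in compounds carrying the phenyl or pentyl group. Also open, from the compounds shown here alone, is how this aromatic carbon would respond to a different substituent, such as a carboxylic acid, a primary amine or a longer aminoalkyl chain.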